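The compounds below may be only part of what the source reports. "The series", "measured", "known", "first", "only" and "open" are said of these compounds alone.

Compound 2 `CC(C)c1ccc(-n2nc(-c3ccc(C(F)(F)F)cc3O)nc2-c2ccccc2O)cc1` gives 108% in a functional assay on PC-12 cells (Rattus norvegicus) for cytotoxicity, read by MTT assay, with stated times of 2 h and 24 h, tested at 10 uM (on this read-out higher numbers stand for a stronger effect at the one concentration tested and lower numbers for a weaker effect), the highest of the three numbers: compound 1 `Cc1ccc(-n2nc(-c3ccc(C(F)(F)F)cc3O)nc2-c2ccccc2O)cc1` gives 102% and compound 3 `COc1ccccc1-n1nc(-c2ccc(C(F)(F)F)cc2O)nc1-c1ccccc1O` gives 96.2% in this assay. The step of a number 6 percentage points higher from compound 1 to compound 2 (within the scatter) lies within the scatter, and so does a number 5.8 percentage points lower from compound 1 to compound 3 (within the scatter), whereas a number 11.8 percentage points lower from compound 2 to compound 3 (beyond the scatter) lies beyond it. Compound 4 `COc1cccc(-n2nc(-c3ccc(C(F)(F)F)cc3O)nc2-c2ccccc2O)c1` is not yet measured; it differs from compound 2 by 3-methoxyphenyl in place of 4-isopropylphenyl on an aromatic nitrogen. The step of a number 11.8 percentage points lower from compound 2 to compound 3 (beyond the scatter) bears most directly on this change, since it too replaces the 4-isopropylphenyl on the aromatic nitrogen with a methoxyphenyl. A modest drop in this assay is therefore expected, about a number 10 percentage points lower from compound 2 to compound 4 (within the scatter). Compound 4 is expected to give roughly 98% in this assay, within a range from 86% to 110%.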

Compound 4, a percentage reported as activity, at one concentration (the size of the read-out at that concentration, not a potency): 106%
The estimate for compound 4 lay 8 percentage points below the measured number, within the range that was stated.
By their numbers in this assay, from the lowest: compounds 3, 1, 4 and 2 (each within the scatter of the next, the first and the last beyond it).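

With the 3-methoxyphenyl on the aromatic nitrogen, this assay shows a number 2 percentage points lower from compound 2 to compound 4 (within the scatter) and a number 4 percentage points higher from compound 1 to compound 4 (within the scatter) and so gives no sign that a methoxyphenyl here lowers the number by itself. The earlier step beyond the scatter is thus confined to the 2-methoxyphenyl, yet a number 9.8 percentage points higher from compound 3 to compound 4 (within the scatter) means that the two methoxyphenyl groups cannot be told apart either. Nothing at hand explains these numbers.

From the compounds shown here alone, whether a 4-methoxyphenyl, or a phenyl carrying an amine or a carboxylic acid, would keep the number in this range remains open.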